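A few compounds are considered here, and "the series" means these few. Any claim that something is new, unique, unknown or untested is made for them only; others in the source may bear on it.

Measured so far in a functional assay on KBVIN cells (Homo sapiens) for antiproliferative activity, read by sulforhodamine B assay, with a stated time of 3 days (a lower number here means that less compound is needed, a higher number that more compound is needed for the effect), for this series
Compound 1 `CCC1=C(O)c2c(oc(-c3ccc(C)cc3)cc2=O)C(CC)(CC)C1=O` gives 0.08 uM
Compound 2 `CCC1=C(O)c2c(oc(-c3ccc(C(C)C)cc3)cc2=O)C(CC)(CC)C1=O` gives 1.08 uM
Compound 3 `CCC1=C(O)c2c(oc(-c3cccc(C)c3)cc2=O)C(CC)(CC)C1=O` gives 3.69 uM

Compound 3 holds the highest number of the three, with a 3.4-fold higher number from compound 2 to compound 3 (0.53 log units; beyond the scatter) as a modest step and a 46-fold higher number from compound 1 to compound 3 (1.66 log units; beyond the scatter) as a large one. Compound 4 `CCC1=C(O)c2c(oc(-c3cccc(OC(F)(F)F)c3)cc2=O)C(CC)(CC)C1=O` carries trifluoromethoxy in place of methyl on an aromatic carbon, meta to a large group, and the change counts as trifluoromethoxy in place of methyl on an aromatic carbon in full. Among the compounds with values here, no measured step makes this exchange. The nearest is a 14-fold higher number from compound 1 to compound 2 (1.13 log units; beyond the scatter) as a large step, where isopropyl takes the place of methyl, but that exchange starts from the 4-methylphenyl group of compound 1 and not from the 3-methylphenyl group of compound 3. It is a single example of a higher number when a larger group replaces methyl. Compound 3 with 3.69 uM as its value already lies far from compound 1, and a step of that size is not carried over. A small step toward a higher number is expected, not clearly beyond the scatter, and a 1.4-fold higher number from compound 3 to compound 4 (0.13 log units; within the scatter) is the estimated step here. For compound 4 the estimated value is 5 uM with an expected range from 1.5 uM to 15 uM in this assay for this series.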

Compound 4, concentration for half-maximal effect: 9.95 uM
The estimate for compound 4 lay 2.0-fold (0.30 log units) below the measured number; measured number inside the range.
By their numbers in this assay, from the lowest: compound 1; then compound 2; then compound 3; then compound 4.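

In this assay, trifluoromethoxy in place of methyl on an aromatic carbon, meta to a large group, gives a 2.7-fold higher number from compound 3 to compound 4 (0.43 log units; beyond the scatter) and is the only exchange of the group itself at this position among the compounds shown. Compound 3 already held the highest number before this exchange, and the new group raises it further, so the number at this position has not yet turned back toward that of compound 1. The step is much smaller than a 46-fold higher number from compound 1 to compound 3 (1.66 log units; beyond the scatter), so in these compounds moving the methyl counts for more than this exchange at the new position, and nothing at hand explains the rise.

On these data alone, two points stay open: whether the same exchange from compound 1 would raise the number by a similar amount or by a very different one, and whether a single example at this position says anything about larger groups in general. Also open, as far as these compounds go, is how a methoxy group, a chlorine atom, an amine or a carboxylic acid would behave on this same aromatic carbon, with the shared core left unchanged.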